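The compounds below may be only part of what the source reports. "The series", "measured", "known", "first", "only" and "open" are said of these compounds alone.

Compounds measured in a functional assay on MDA-MB-231 cells (Homo sapiens) for cytotoxicity, read by MTT assay, with a stated time of 48 h; on this read-out lower numbers stand for stronger inhibition and higher numbers for weaker inhibition:
compound 1 `O=C(/C=C\Nc1cnc2ccccc2c1)c1nc(-c2ccccc2)n2ccccc12` gives 12300 nM
compound 2 `COc1ccc(-c2nc(C(=O)/C=C\Nc3ccc(Cl)cc3)c3ccccn23)cc1` gives > 30000 nM, which is a limit of the assay and not a number
compound 3 `O=C(/C=C\Nc1ccc(Cl)cc1)c1nc(-c2ccc(C(F)(F)F)cc2)n2ccccc12` gives 3840 nM

Among the two numbers, compound 1 stands highest, with compound 3 at a lower number beyond the scatter. Compound 4 `COc1ccc(N/C=C\C(=O)c2nc(-c3ccccc3)n3ccccc23)cc1` differs from compound 1 by 4-methoxyphenyl in place of quinolin-3-yl on an amine nitrogen. Within the data shown here, the only measured step, an at least 7.8-fold lower number from compound 2 to compound 3 (0.89 log units; beyond the scatter), changes the aryl on the core, not the group on the amine nitrogen, so no measured step bears directly on this change. The account therefore expects compound 4 to sit near compound 1, with the step of a 1.1-fold higher number from compound 1 to compound 4 (0.06 log units; within the scatter) estimated as not beyond the scatter, and the estimate for compound 4 is 14000 nM (range 4000 nM to 30000 nM), with some chance of a limit because the limit of > 30000 nM in this assay, at which 1 of the 3 values shown sits, is reached by one compound here.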

Compound 4, half-maximal inhibitory concentration: 28300 nM
Estimate against measurement, compound 4: 2.0-fold (0.31 log units) below; low and high end bracket the measured number.
By their numbers in this assay, from the lowest: compound 3; then compound 1; then compound 4. At a limit, above all of these: compound 2.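

In this assay the group on the amine nitrogen proves not to be silent: 4-methoxyphenyl in place of quinolin-3-yl gives a 2.3-fold higher number from compound 1 to compound 4 (0.36 log units; beyond the scatter). Among these compounds, this is the first measured change at this position, and the earlier step touched only the aryl on the core. Nothing shown here gives a cause for this step.

Going by these compounds, it remains open whether a plain phenyl or a pyridin-3-yl on the amine nitrogen would read nearer compound 1 or compound 4. On these data alone, it is also open whether the same change would carry over to a core bearing trifluoromethyl on its aryl.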